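Chloro-substituted purine benzyl chlorides: growth inhibition notes

The source may hold more compounds than are shown below. What is called first, only, known or untested is meant among the compounds shown, and "the series" means these compounds.

Measured so far:
compound 1 `ClCc1ccc(Cn2cnc3c(Cl)ncnc32)cc1` — 5620 nM
compound 2 `ClCc1cccc(Cn2cnc3c(Cl)ncnc32)c1` — 15100 nM

Within the data shown here, in a functional assay on BT-549 cells (Homo sapiens) for cytotoxicity, read by sulforhodamine B assay, with a stated time of 48 h (a lower number here means a stronger inhibitor of growth, a higher number a weaker inhibitor of growth), compound 1 gives 5620 nM, the lowest of the two numbers so far. Compound 2, with the same core and the same chloromethyl-bearing benzyl group, gives 15100 nM in this assay, a higher number, and the gap between compound 1 and compound 2 lies beyond the usual scatter.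

Compound 3 `ClCc1ccc(Cn2cnc3c(Cl)nc(Cl)nc32)cc1` has not yet been measured in this assay. Relative to compound 1, the change is chloro in place of hydrogen on an aromatic carbon, between two ring nitrogen atoms of the fused core, meta to the chloro group already present.

Among the measured compounds shown here, no pair of measured compounds differs by such a change, so there is no measured step to lean on. With compound 1 at 5620 nM as the only anchor, the expectation for compound 3 is a small step downward, of a size that may not exceed the scatter, as the step of a 1.6-fold lower number from compound 1 to compound 3 (0.21 log units; within the scatter) is estimated. Compound 3 is therefore expected to give about 3500 nM in this assay, within a range from 1200 nM to 10000 nM.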

Compound 3, concentration for 50% growth inhibition: 15900 nM
For compound 3 the middle estimate is 4.5-fold (0.66 log units) below the measured one, and the stated range ends below it.
By their numbers in this assay, from the lowest: compound 1; then compounds 2 and 3 (each within the scatter of the next).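

In this assay the series now has its first readable change on the shared core: chloro in place of hydrogen on the aromatic carbon between two ring nitrogen atoms gives a 2.8-fold higher number from compound 1 to compound 3 (0.45 log units; beyond the scatter) and so moves growth inhibition the wrong way. This position is therefore not indifferent to substitution, and on the evidence of this one pair, hydrogen serves better there than chloro, although a single step sets no trend. Nothing available on these compounds accounts for the size or direction of this step.

Going by these compounds, it remains open whether this loss is specific to chloro or follows any replacement of hydrogen at this position, a question that an amine, a methoxy group or a methyl group there would help to settle. On these data alone, it is equally open whether the same step would appear with the chloromethyl-bearing benzyl group of compound 2, since the present pair rests only on the benzyl group of compound 1.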